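Compound 2 to compound 4: aryl exchange on the chain carbon

This account rests on a few compounds, and the source may have more. Where it says the series, first, only, none or still open, it means among the compounds named here.

Three compounds of the series have entries in a functional assay on MOLT-4 cells (Homo sapiens) for cytotoxicity, read by CCK-8 assay, with a stated time of 72 h (on this read-out lower numbers stand for stronger inhibition and higher numbers for weaker inhibition), but only one of them carries a number. Compound 1 `C=CCn1c(=O)/c(=C\c2ccc(Cl)c(Cl)c2)[nH]c(=O)/c1=C\c1ccccc1` is recorded in this assay as "not active" (no number reported), without a value. Compound 3 `COc1ccccc1/C=c1\c(=O)[nH]/c(=C/c2ccccc2Cl)c(=O)n1C` has no result in this assay, its entry reading "not determined" (no result reported). Compound 2 `C=CCn1c(=O)/c(=C\c2cc(F)ccc2C)[nH]c(=O)/c1=C\c1ccccc1OC` is therefore the one fixed point: in this assay compound 2 gives 3800 nM, and no second number exists to set it against, so nothing can be said about where it stands relative to the other two beyond that they show no value.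

Compound 4 `C=CCn1c(=O)/c(=C\c2ccccc2C(F)(F)F)[nH]c(=O)/c1=C\c1ccccc1OC` is not yet measured. It differs from compound 2 in one place: 2-(trifluoromethyl)phenyl in place of 5-fluoro-2-methylphenyl on a double-bonded chain carbon bound to an aromatic carbon. Within the data shown here, no step between two measured compounds is available that would show how an exchange of this kind moves the read-out, so the expectation rests on compound 2 alone.

The step is expected to be small, with no direction that can be trusted beyond the scatter; the change from compound 2 to compound 4 is estimated at a 1.1-fold higher number from compound 2 to compound 4 (0.02 log units; within the scatter). Compound 4 is thus expected to give about 4000 nM in this assay, within a range of 1500 nM to 12000 nM, with a fair chance that, like compound 1, only an inactive entry is reported.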

Compound 4, half-maximal inhibitory concentration: 4400 nM
Estimate against measurement, compound 4: 1.1-fold (0.04 log units) below; measured number inside the range.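

In this assay, among these compounds, the exchange of 5-fluoro-2-methylphenyl for 2-(trifluoromethyl)phenyl on a double-bonded chain carbon bound to an aromatic carbon gives a 1.2-fold higher number from compound 2 to compound 4 (0.06 log units; within the scatter) and is the first step that can be read at all. At this place, with the rest of the molecule unchanged, a group of 10 heavy atoms with 3 fluorine stands in for one of 8 heavy atoms with 1 fluorine, and the read-out does not separate the two, so this one pair gives no sign that the difference between these two aryl groups matters here. Nothing on hand gives a reason for this result.

Open, from the compounds shown here alone, is whether the same place stays as flat with a group of another kind, such as a phenyl ring carrying a carboxylic acid or an amine, since both aryl groups seen here carry only carbon and fluorine substituents. Also open, going by these compounds, is how far this single pair speaks for other aryl groups on the shared core, and what separates these two compounds from the inactive entry of compound 1, which differs from both in more than one place.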